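Working notes: 3-hydroxyphenyl to 4-hydroxyphenyl

This account rests on a few compounds, and the source may have more. Where it says the series, first, only, none or still open, it means among the compounds named here.

In an ADME assay on NHDF cells (Homo sapiens) for cytotoxicity, read by MTT assay, with a stated time of 72 h (on this read-out higher numbers stand for weaker inhibition and lower numbers for stronger inhibition), compound 3 (`COc1ccc(/C=C2\CCC/C(=C\c3cccc(O)c3)C2=O)cc1OC`) gives 6800 nM, within the scatter of compound 1 (`COc1cccc(/C=C2\CCC/C(=C\c3ccc(OC)c(OC)c3)C2=O)c1`) at 11600 nM. Compound 2 (`COc1ccc(/C=C2\CCC/C(=C\c3ccc(OC)c(OC)c3)C2=O)cc1`) stands apart at 30900 nM, with a 4.5-fold lower number from compound 2 to compound 3 (0.66 log units; beyond the scatter). Compound 4 (`COc1ccc(/C=C2\CCC/C(=C\c3ccc(O)cc3)C2=O)cc1OC`) has 4-hydroxyphenyl in place of 3-hydroxyphenyl on a double-bonded chain carbon bound to a double-bonded ring carbon. Among the measured compounds shown here, the only precedent is the matching 3-methoxyphenyl to 4-methoxyphenyl change, showing a 2.7-fold higher number from compound 1 to compound 2 (0.43 log units; beyond the scatter). The other single change, hydrogen in place of methyl, shows a 1.7-fold lower number from compound 1 to compound 3 (0.23 log units; within the scatter), so the two methoxyphenyl results offer a fair guide, though from one pair only. A modest rise is expected, a little smaller than that precedent, namely a 2.2-fold higher number from compound 3 to compound 4 (0.34 log units; beyond the scatter). The estimate for compound 4 is 15000 nM, with an expected range of 6500 nM to 33000 nM.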

Compound 4, half-maximal inhibitory concentration: 26100 nM
Beside the measured number, compound 4's estimate is 1.7-fold (0.24 log units) below it; the measured number falls inside the stated range.
By their numbers in this assay, from the lowest: compounds 3 and 1 (each within the scatter of the next); then compounds 4 and 2 (each within the scatter of the next).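

In this assay 4-hydroxyphenyl in place of 3-hydroxyphenyl also raises the number (a 3.8-fold higher number from compound 3 to compound 4 (0.58 log units; beyond the scatter)), and so does 4-hydroxyphenyl in place of 3-methoxyphenyl (a 2.3-fold higher number from compound 1 to compound 4 (0.35 log units; beyond the scatter)). The rise at this double-bonded chain carbon therefore holds for the hydroxyphenyl pair as well as the methoxyphenyl pair, with all four compounds fitting. Hydrogen in place of methyl stays within the scatter (a 1.2-fold lower number from compound 2 to compound 4 (0.07 log units; within the scatter)), and it reads alike on both cores: the same change on two cores in this assay, a 1.7-fold lower number (0.23 log units; within the scatter) from compound 1 to compound 3 and a 1.2-fold lower number (0.07 log units; within the scatter) from compound 2 to compound 4, 1.4-fold (0.16 log units) apart, within the scatter of two such steps. Still open, from the compounds shown here alone, is whether an aminophenyl or a carboxylic acid on this ring follows the same order.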